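Swapping chloro for bromo on a second sulfonamide core

A few compounds are considered here, and "the series" means these few. Any claim that something is new, unique, unknown or untested is made for them only; others in the source may bear on it.

Of the compounds shown here, three have been measured in an ADME assay on MDCK cells (Canis lupus familiaris) for cytotoxicity, read by MTT assay, with a stated time of 24 h; a higher number here means that more compound is tolerated, a lower number that less compound is tolerated. Compound 1 `Cc1cc(CNS(=O)(=O)c2ccc(Cl)cc2)c(C)o1` gives 55700 nM. Compound 2 `Cc1cc(CNS(=O)(=O)c2ccc(Br)cc2)c(C)o1` differs from compound 1 by bromo in place of chloro on an aromatic carbon; in this assay compound 2 gives 29600 nM, and the step of a 1.9-fold lower number from compound 1 to compound 2 (0.27 log units; within the scatter). Compound 3 `O=S(=O)(NCc1csc2ccccc12)c1ccc(Cl)cc1` carries a different core, and the difference between the two cores is not broken down here; in this assay compound 3 gives 69600 nM.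

Compound 4 `O=S(=O)(NCc1csc2ccccc12)c1ccc(Br)cc1` has not yet been measured. It differs from compound 3 by bromo in place of chloro on an aromatic carbon, the same change that leads from compound 1 to compound 2, made on the same kind of place. Among the measured compounds shown here, the only guide to its size is the measured pair: compound 1 to compound 2 moved within the scatter. The expectation is therefore a step of similar size on the new core, a 1.7-fold lower number from compound 3 to compound 4 (0.24 log units; within the scatter), resting on the value of compound 3 at 69600 nM and the earlier step. Compound 4 is expected to give about 40000 nM, most likely between 20000 nM and 80000 nM.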

Compound 4, half-maximal cytotoxic concentration: 87100 nM
Compound 4: the middle estimate sits 2.2-fold (0.34 log units) below what was measured, outside the stated range (above it).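

In this assay, putting bromo in place of chloro on the second core gives a 1.3-fold higher number from compound 3 to compound 4 (0.10 log units; within the scatter), so here too the swap leaves the number inside the usual spread of repeated measurements. On paper the two steps point in opposite directions, but neither the steps nor the gap between them stand out from that spread: the same change on two cores in this assay, a 1.9-fold lower number (0.27 log units; within the scatter) from compound 1 to compound 2 and a 1.3-fold higher number (0.10 log units; within the scatter) from compound 3 to compound 4, 2.4-fold (0.37 log units) apart, within the scatter of two such steps. This shows that, on these two cores, going from 4-chlorophenyl to 4-bromophenyl produces no shift in tolerated concentration that can be told apart from scatter, but it does not prove that the swap has no effect at all, nor that the two cores respond either alike or differently.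

The compounds shown vary this position only between chloro and bromo, so what a larger departure such as an amine or a carboxylic acid would do in the same place remains open. Also open, from the compounds shown here alone, is whether the swap would stay this small on a third core.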